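This account rests on a few compounds, and the source may have more. Where it says the series, first, only, none or still open, it means among the compounds named here.

Compound 1, `CC(C)C(Cc1ncc[nH]1)c1ccc(-c2ccc3cccc(F)c3c2)[nH]c1=O`, gives 0.106 h in an ADME assay on microsomes from liver (Homo sapiens) for metabolic stability; on this read-out lower numbers stand for a shorter-lived compound and higher numbers for a longer-lived compound.
Compound 2, `CCC(CC)(c1nnc[nH]1)c1ccc(-c2ccc3cccc(F)c3c2)[nH]c1=O`, gives 1.19 h in this assay.
Compound 3, `CCn1ncc2c(F)cc(-c3ccc(C(CC)(CC)c4nnc[nH]4)c(=O)[nH]3)cc21`, gives 2.7 h in this assay.

Among these three, compound 1 stands at the bottom: compound 2 lies above it by a margin beyond the usual scatter, and compound 3 lies further above still, also beyond the scatter. Compound 4, `CC(C)C(Cc1nnc[nH]1)c1ccc(-c2ccc3cccc(F)c3c2)[nH]c1=O`, is the next compound to be measured. It differs from compound 1 in one place: 4H-1,2,4-triazol-3-yl in place of 1H-imidazol-2-yl on a saturated chain carbon, two bonds along the chain from an aromatic carbon. For the measured compounds named here, no measured pair shows this exact change on its own, so the size of the step in this assay is not fixed by the data. Compound 2 does carry the 4H-1,2,4-triazol-3-yl group and gives 1.19 h, but it also carries a different chain, so only part of its gap to compound 1 can be read onto compound 4. An upward step of modest size, a 2.8-fold higher number from compound 1 to compound 4 (0.45 log units; beyond the scatter), is expected for compound 4, with wide uncertainty. Compound 4 is therefore estimated at 0.3 h, in the range 0.1 h to 1 h.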

Compound 4, half-life: 0.307 h
Compound 4: middle estimate off by 1.0-fold (0.01 log units), on the low side, and the stated range covers the measured number.
By their numbers in this assay, from the lowest: compound 1; then compound 4; then compound 2; then compound 3.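

Replacing 1H-imidazol-2-yl with 4H-1,2,4-triazol-3-yl on a saturated chain carbon, two bonds along the chain from an aromatic carbon, gives in this assay a clean reading of a 2.9-fold higher number from compound 1 to compound 4 (0.46 log units; beyond the scatter) and counts as a modest step. For the compounds shown here, this is the first time the ring change is seen with the chain and the rest of the molecule held constant, something the earlier compounds, with no pair differing in one place, could not show. Nothing measured here gives a reason for the step.

Whether the step keeps its size on the chain carried by compound 2 stays open, since no imidazole partner for that compound is shown. Also open, on these data alone, is how a tetrazole, a carboxylic acid or a primary amide would read at this same place.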